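Lengthening the Ether Chain from Compound 2 to Compound 3

A few compounds are considered here, and "the series" means these few. Any claim that something is new, unique, unknown or untested is made for them only; others in the source may bear on it.

Compound 1 `CCOc1cc(C(C)=O)ccc1NS(C)(=O)=O` and compound 2 `CCCOc1cc(C(C)=O)ccc1NS(C)(=O)=O` share one core and differ only in their ether chain. In a functional assay on the whole organism (strain Wistar) for inhibition, with Rattus norvegicus as the target, read by paw edema, with stated times of 30 min and 5 h, at a dose of 75 mg/kg by the oral route (on this read-out higher numbers stand for a stronger effect at the one dose given and lower numbers for a weaker effect), compound 1 gives 66.3%, and compound 2 gives 67.2%; compound 2 stands alongside compound 1, the step of a number 0.9 percentage points higher from compound 1 to compound 2 (within the scatter) lying within the scatter. Compound 3 `CCCCCCCCOc1cc(C(C)=O)ccc1NS(C)(=O)=O` lengthens the chain further: pentyl in place of hydrogen on a saturated chain carbon, three bonds along the chain from an oxygen on an aromatic ring. Going by the values given here, the only step that bears on this change, a number 0.9 percentage points higher from compound 1 to compound 2 (within the scatter), stayed within the scatter, so a further extension is expected to give no step beyond the scatter, a number 3.2 percentage points lower from compound 2 to compound 3 (within the scatter). Compound 3 is therefore estimated at 64%, between 45% and 80%.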

Compound 3, a percentage reported as inhibition, in the whole organism at one dose (the size of the read-out at that dose, not a potency): 69.9%
Compound 3: the middle estimate sits 5.9 percentage points below what was measured; measured number inside the range.
By their numbers in this assay, from the lowest: compounds 1, 2 and 3 (each within the scatter of the next).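

In this assay, pentyl in place of hydrogen gives a number 2.7 percentage points higher from compound 2 to compound 3 (within the scatter) and hexyl in place of hydrogen, read over the whole extension, gives a number 3.6 percentage points higher from compound 1 to compound 3 (within the scatter) on the same read-out. The earlier step covered only methyl, whereas these show that even a far longer saturated chain on this ether oxygen stays within the scatter of the shorter chains at this one dose. From the compounds shown here alone, whether a longer chain, or a chain ending in an amine or a carboxylic acid, would leave that scatter remains open. Nothing shown here explains why the read-out stays so flat.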